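The source may hold more compounds than are shown below. What is called first, only, known or untested is meant among the compounds shown, and "the series" means these compounds.

Measured in a functional assay on CCRF-CEM cells (Homo sapiens) for cytotoxicity, read by XTT assay, with a stated time of 3 days; a higher number here means a weaker inhibitor, a lower number a stronger inhibitor:
- compound 1 `OC[C@H]1O[C@@H](n2cc(F)c3c(-c4cccs4)ncnc32)[C@H](O)[C@@H]1O`: 270 nM
- compound 2 `OC[C@H]1O[C@@H](n2cc(F)c3c(-c4ccoc4)ncnc32)[C@H](O)[C@@H]1O`: 1000 nM
- compound 3 `OC[C@H]1O[C@@H](n2cc(F)c3c(-c4cc[nH]c4)ncnc32)[C@H](O)[C@@H]1O`: 930 nM

Compound 1 holds the lowest of the three numbers. Exchanging its thiophen-2-yl gives a 3.7-fold higher number from compound 1 to compound 2 (0.57 log units; beyond the scatter) for furan-3-yl and a 3.4-fold higher number from compound 1 to compound 3 (0.54 log units; beyond the scatter) for 1H-pyrrol-3-yl, both modest and beyond the scatter. The remaining step, a 1.1-fold lower number from compound 2 to compound 3 (0.03 log units; within the scatter), stays within the scatter.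

Compound 4 `OC[C@H]1O[C@@H](n2cc(Cl)c3c(-c4cccs4)ncnc32)[C@H](O)[C@@H]1O` keeps the thiophen-2-yl of compound 1 and changes one other place: chloro in place of fluoro on an aromatic carbon. This is chloro in place of fluoro on an aromatic carbon of the five-membered aromatic ring with 1 nitrogen.

Among the measured compounds shown here, no measured step changes this halogen, since all three exchange a different group, so the data give only indirect guidance. The largest of them, a 3.7-fold higher number from compound 1 to compound 2 (0.57 log units; beyond the scatter), is modest. In this assay a step no larger than that is therefore expected, most likely none beyond the scatter, with neither direction favoured. The estimate amounts to a 1.1-fold lower number from compound 1 to compound 4 (0.03 log units; within the scatter), an expected step that stays small. For compound 4 the estimated value is 250 nM, with an expected range from 80 nM to 800 nM.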

Compound 4, half-maximal inhibitory concentration: 2700 nM
For compound 4 the middle estimate is 11-fold (1.03 log units) below the measured one; measured number outside the range, above it.
By their numbers in this assay, from the lowest: compound 1; then compounds 3 and 2 (each within the scatter of the next); then compound 4.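

In this assay, the halogen on this aromatic carbon of the five-membered aromatic ring with 1 nitrogen proves to be a sensitive place: with the thiophen-2-yl held constant, chloro in place of fluoro gives a 10-fold higher number from compound 1 to compound 4 (1.00 log units; beyond the scatter). That step is larger than either exchange of the thiophen-2-yl, a 3.7-fold higher number from compound 1 to compound 2 (0.57 log units; beyond the scatter) and a 3.4-fold higher number from compound 1 to compound 3 (0.54 log units; beyond the scatter), so within these compounds the halogen matters more than the choice among the three aromatic rings shown. Fluoro and chloro have the same counts of heavy atoms, hydrogen-bond donors and hydrogen-bond acceptors and carry no net charge, so these counts do not separate them, and no measurement available here accounts for the difference.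

The compounds shown leave open whether chloro raises the number to a similar extent when paired with furan-3-yl or 1H-pyrrol-3-yl, since this halogen exchange is seen only with thiophen-2-yl. They also leave open how hydrogen, bromo, methyl or nitrile at the same carbon would compare with fluoro and chloro.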